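The source may report more compounds than this note shows. Statements on the series, on what has been measured and on what is new or still open speak of the compounds shown alone.

Compound 1 `Nc1nc(NCCNc2ncc(-c3ncc[nH]3)c(-c3ccccc3Cl)n2)ccc1[N+](=O)[O-]`: > 0.5 h
Compound 2 `Nc1nc(NCCNc2ncc(-c3ncc[nH]3)c(-c3ccccc3Br)n2)ccc1[N+](=O)[O-]`: > 0.5 h
Compound 3 `Nc1nc(NCCNc2ncc(-c3ncc[nH]3)c(-c3ccc(F)cc3F)n2)ccc1[N+](=O)[O-]`: > 0.5 h

These three compounds were tested in an ADME assay on microsomes from liver (Canis lupus familiaris) for metabolic stability; on this read-out lower numbers stand for a shorter-lived compound and higher numbers for a longer-lived compound. In this assay compound 3 gives > 0.5 h, which is a limit and not a number. Compound 3 therefore has no exact place in the series. It shares this position with compound 1 and compound 2, as the whole set stands at the limit of > 0.5 h in this assay, at which 3 of the 3 values shown sit.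

Compound 4 `Nc1nc(NCCNc2ncc(-c3ncc[nH]3)c(-c3cc(F)ccc3Cl)n2)ccc1[N+](=O)[O-]` has not yet been measured and differs from compound 3 in one place: 2-chloro-5-fluorophenyl in place of 2,4-difluorophenyl on an aromatic carbon. Here 2-chloro-5-fluorophenyl stands in place of 2,4-difluorophenyl, on an aromatic carbon ortho to a 1H-imidazol-2-yl group.

The closest guide among the measured changes is a step that the two limits leave unreadable from compound 1 to compound 3, which also exchanges 2,4-difluorophenyl and a chlorinated phenyl. The other two are a step that the two limits leave unreadable from compound 1 to compound 2 and a step that the two limits leave unreadable from compound 2 to compound 3. None of the three has a readable size, so they give no direction, and no change beyond the usual scatter is expected. The expected outcome is a step that the limit leaves unreadable from compound 3 to compound 4. Another limit is the most likely report for compound 4. In this assay compound 4 is estimated at 0.7 h, with an expected range from 0.4 h to 1.2 h.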

Compound 4, half-life: > 0.5 h
Compound 4: only a limit was reported; the forecaster's own chance of this, stated with the estimate: 85%; the middle value is on the limit's open side.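

In this assay compound 4 gives > 0.5 h, which is a limit, so its steps to compound 1, compound 2 and compound 3 cannot be read, and the set stays together: the limit of > 0.5 h in this assay, at which 4 of the 4 values shown sit.

The compounds shown leave open the actual half-life of each of the four, and whether any of these phenyl changes alters it.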